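Swapping the methoxyphenyl end of a curcumin-like chain

This account rests on a few compounds, and the source may have more. Where it says the series, first, only, none or still open, it means among the compounds named here.

Of the compounds shown here, three have been tested in a functional assay on COLO 205 cells (Homo sapiens) for inhibition, read by sulforhodamine B assay, with a stated time of 48 h, tested at 50 uM; on this read-out higher numbers stand for more inhibition of growth at the one concentration tested and lower numbers for less inhibition of growth. Compound 1 `COc1ccccc1/C=C/C(=O)/C=C/c1ccc(OCc2cn(CCCOc3cc(=O)oc4ccccc34)nn2)c(OC)c1` gives 57%, compound 3 `COc1ccccc1/C=C/C(=O)/C=C/c1ccc(OCc2cn(CCCCOc3cc(=O)oc4ccccc34)nn2)c(OC)c1` gives 47%, and compound 2 `COc1ccc(/C=C/C(=O)/C=C/c2ccc(OCc3cn(CCCCCOc4cc(=O)oc5ccccc45)nn3)c(OC)c2)cc1` gives 30%. Compound 2 stands lowest of the three: the nearest number, that of compound 3, lies higher by an amount beyond the scatter, and the number of compound 1 lies higher still, also beyond the scatter.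

Compound 4 `COc1ccccc1/C=C/C(=O)/C=C/c1ccc(OCc2cn(CCCCCOc3cc(=O)oc4ccccc34)nn2)c(OC)c1` has not yet been measured. Its atoms are the same as those of compound 2, but joined differently: 2-methoxyphenyl in place of 4-methoxyphenyl on a double-bonded chain carbon bound to a double-bonded chain carbon. Among the compounds with values here, no directly comparable pair of measured compounds exists for this particular change, so the direction must be judged loosely. Compounds 1 and 3 both carry the entering 2-methoxyphenyl group and both give higher numbers than compound 2, yet they differ from compound 2 in more than this one place, so they are only a rough guide.

On that basis, the move from compound 2 to compound 4 is expected to raise growth inhibition modestly, with an expected step of a number 12 percentage points higher from compound 2 to compound 4 (beyond the scatter), which may reach just beyond the scatter. For compound 4 the expected value in this assay is 42%, in a range from 27% to 57%.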

Compound 4, percent growth inhibition at one concentration: 30%
For compound 4 the middle estimate is 12 percentage points above the measured one, within the range that was stated.
By their numbers in this assay, from the lowest: compounds 2 and 4 (each within the scatter of the next); then compounds 3 and 1 (each within the scatter of the next).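

Here, for the first time, two compounds differ in one place only, and in this assay the 2-methoxyphenyl group in place of the 4-methoxyphenyl group on a double-bonded chain carbon bound to a double-bonded chain carbon gives no change at the digits printed from compound 2 to compound 4 (within the scatter), so with this linking chain the two groups cannot be told apart. Compound 4 also carries the same 2-methoxyphenyl group as compound 1 and compound 3, which differ from it in the length of the linking chain, so this group alone does not go with the higher numbers of those two compounds. Nothing available explains why the change leaves the number where it stands.

The compounds shown leave open whether the same swap would also make no difference with the shorter linking chains of compound 1 and compound 3, whose 4-methoxyphenyl partners are not among them. They also leave open what a plain phenyl group, or a phenyl group carrying a dimethylamino group or a carboxylic acid, would do at this place.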